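The source may report more compounds than this note shows. Statements on the series, on what has been measured and on what is new or still open speak of the compounds shown alone.

Compounds measured in an ADME assay on Raji cells (Homo sapiens) for cytotoxicity, read by CellTiter-Glo and resazurin assay, with a stated time of 72 h; on this read-out higher numbers stand for an effect only at larger amounts of compound and lower numbers for an effect already at smaller amounts:

- Compound 1 `CCOC(=O)CCCCCOc1cccc(CN(C(=O)c2ccc(-c3ccncc3)cc2)C(C)C)c1`: > 26000 nM, a limit
- Compound 2 `CCOC(=O)CCCCCOc1cccc(CN(C(=O)c2ccc(-c3ccco3)cc2)C(C)C)c1`: > 26000 nM, a limit
- Compound 3 `CCOC(=O)CCCCCOc1cccc(CN(C(=O)c2ccc(-c3cccc(O)c3)cc2)C(C)C)c1`: > 26000 nM, a limit

Compound 3 offers no exact number to start from, only the limit > 26000 nM. It shares this position with the other two compounds, and the overall picture is the limit of > 26000 nM in this assay, at which 3 of the 3 values shown sit.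

Compound 4 `CCOC(=O)CCCCCOc1cccc(CN(C(=O)c2ccc(-c3cccc(F)c3)cc2)C(C)C)c1` is still to be measured. It differs from compound 3 in a single place: fluoro in place of hydroxy on an aromatic carbon. Put simply, the 3-hydroxyphenyl group becomes a 3-fluorophenyl group.

Among the compounds with values here, three measured steps bear on this change, since each swaps one aromatic group for another at the place where this group sits: a step that the two limits leave unreadable from compound 1 to compound 2, a step that the two limits leave unreadable from compound 1 to compound 3 and a step that the two limits leave unreadable from compound 2 to compound 3. None of them has a size that can be read, so they give no direction for the new change. Even so, three different groups at this place have all ended at the same limit, and a change of one atom within the group of compound 3 is expected to do little in this assay. The expected result is a number no higher from compound 3 to compound 4 (the limit leaves the size open), with no shift beyond the usual scatter in either direction. For compound 4 the estimated value is 26000 nM, with an expected range of 10000 nM to 50000 nM, and a report as a limit alone is the likeliest outcome.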

Compound 4, half-maximal effective concentration: > 26000 nM
Compound 4 was reported as a limit (the forecaster's own chance of this, stated with the estimate: 85%); the middle value sits exactly at the limit.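

Within the data shown here, compound 4 is reported only as a limit in this assay, like compound 1, compound 2 and compound 3, so no step from those compounds to compound 4 can be read. All four compounds sit at the same point: the limit of > 26000 nM in this assay, at which 4 of the 4 values shown sit. The compounds shown leave open whether these aromatic groups differ at all in this assay.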